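Benzyl ether variation on an oxime-linked quinazoline series

The source may hold more compounds than are shown below. What is called first, only, known or untested is meant among the compounds shown, and "the series" means these compounds.

Measured so far:
compound 1 `Clc1ccc(COc2ccc(/C=C/C(/C=C/c3ccccn3)=N/Oc3ncnc4ccccc34)cc2)cc1` — 94.4%
compound 2 `Clc1ccc(COc2ccc(/C=C/C(/C=C/c3ccccn3)=N/Oc3ncnc4cc(Cl)ccc34)cc2)cc1` — 88.1%

Both compounds were run in a functional assay on SMMC-7721 cells (Homo sapiens) for inhibition, read by MTT assay, with a stated time of 72 h, tested at 10 uM; a lower number here means a weaker effect, a higher number a stronger effect of the compound at the concentration tested. Among the measured compounds shown here, compound 2 gives 88.1%, and the only measured neighbour is compound 1, the change being a number 6.3 percentage points lower from compound 1 to compound 2 (within the scatter); the two numbers therefore cannot be told apart, and the pair shows nothing about the benzyl ether end of the shared core.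

Compound 3 `Fc1ccccc1COc1ccc(/C=C/C(/C=C/c2ccccn2)=N/Oc2ncnc3cc(Cl)ccc23)cc1` keeps the chloro on the core of compound 2 and alters that ether: 2-fluorophenyl in place of 4-chlorophenyl on a saturated chain carbon bound to an oxygen on an aromatic ring. For the measured compounds named here, no measured step touches this part of the molecule, so there is no step whose size could be carried over. With compound 2 at 88.1% and nothing to argue for a shift, the expectation is a change of about a number 3.1 percentage points lower from compound 2 to compound 3 (within the scatter), that is none beyond the scatter. Compound 3 is accordingly estimated at 85%, within 68% to 96%.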

Compound 3, a percentage reported as inhibition, at one concentration (the size of the read-out at that concentration, not a potency): 91.2%
Beside the measured number, compound 3's estimate is 6.2 percentage points below it, within the range that was stated.
By their numbers in this assay, from the lowest: compounds 2, 3 and 1 (each within the scatter of the next).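

In this assay, 2-fluorophenyl in place of 4-chlorophenyl on a saturated chain carbon bound to an oxygen on an aromatic ring gives a number 3.1 percentage points higher from compound 2 to compound 3 (within the scatter). Among the compounds shown here, this is the first reading at the benzyl ether end of the series, and it shows that this exchange leaves the read-out indistinguishable from that of compound 2 on the chloro-bearing core. The exchange alters both the halogen and its place on the ring, so the pair cannot separate these two changes, and no measurement shown here offers an explanation for the result.

Open, from the compounds shown here alone, is whether this position keeps the read-out with an unsubstituted phenyl, or with a carboxylic acid or an amine on that ring. Also open, going by these compounds, is whether a longer chain between that ring and the ether oxygen does the same.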